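The source may report more compounds than this note shows. Statements on the series, on what has been measured and on what is new or still open speak of the compounds shown alone.

Compound 1 `CCCn1c(=O)c2[nH]c(Cc3ccccc3)nc2n(Cc2ccco2)c1=O`: 302 nM
Compound 2 `CC(C)Cn1c(=O)c2[nH]c(Cc3ccccc3)nc2n(Cc2ccco2)c1=O`: 490 nM

In an assay on cell membranes for displacement of a labelled ligand from adenosine receptor A1 (Rattus norvegicus) (on this read-out higher numbers stand for weaker inhibition and lower numbers for stronger inhibition), compound 2 stands highest of the two numbers measured; its nearest neighbour is compound 1, and the step of a 1.6-fold higher number from compound 1 to compound 2 (0.21 log units; within the scatter) lies within the scatter. Compound 3 `CCCCCn1c(=O)c2[nH]c(Cc3ccccc3)nc2n(Cc2ccco2)c1=O` differs from compound 2 by butyl in place of isopropyl on a saturated chain carbon bound to an aromatic nitrogen. Going by the values given here, only that one measured step touches the same chain, and it was within the scatter, so no shift beyond the scatter is expected in this assay; a measured step from a branched to a longer straight chain is lacking. The expected step is a 1.3-fold lower number from compound 2 to compound 3 (0.11 log units; within the scatter). Compound 3 is therefore estimated at 380 nM, between 150 nM and 950 nM.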

Compound 3, inhibition constant: 871 nM
Estimate against measurement, compound 3: 2.3-fold (0.36 log units) below; measured number inside the range.
By their numbers in this assay, from the lowest: compounds 1, 2 and 3 (each within the scatter of the next, the first and the last beyond it).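

In this assay, going by these compounds alone, ethyl in place of hydrogen on a saturated chain carbon, three bonds along the chain from an aromatic nitrogen, gives the first step at this position that lies beyond the scatter, though a modest one (a 2.9-fold higher number from compound 1 to compound 3 (0.46 log units; beyond the scatter)). Butyl in place of isopropyl stays within the scatter (a 1.8-fold higher number from compound 2 to compound 3 (0.25 log units; within the scatter)), so the branched isobutyl and straight pentyl chains cannot be told apart here. Nothing available accounts for these steps. Open, on these data alone, is whether a longer chain, such as heptyl, would continue the step seen with pentyl. Also open, as far as these compounds go, is how a chain ending in an amine or a carboxylic acid would read at this position.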